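Two aryl amines, one fluoro-nitrophenyl swap, and an unmeasured partner

The source may report more compounds than this note shows. Statements on the series, on what has been measured and on what is new or still open speak of the compounds shown alone.

The study covers four compounds built around a common diaminopyrimidinol chain, all assessed in a functional assay on CCRF-CEM cells (Homo sapiens) for cytotoxicity, in the absence of a further agent; a lower number here means a stronger inhibitor, a higher number a weaker inhibitor. Compound 3 `COC(=O)c1ccc(CN(CCCc2c(N)nc(N)nc2O)c2cc(F)ccc2[N+](=O)[O-])cc1` gives 45000 nM in this assay. Compound 1 `COC(=O)c1ccc(CN(CCCc2c(N)nc(N)nc2O)c2ccc([N+](=O)[O-])c(F)c2F)cc1` carries 2,3-difluoro-4-nitrophenyl in place of 5-fluoro-2-nitrophenyl on an amine nitrogen and gives 41000 nM in this assay; the step of a 1.1-fold lower number from compound 3 to compound 1 (0.04 log units; within the scatter) is therefore small and falls inside the usual scatter of such measurements. Compound 2 `CC(C)(C)OC(=O)CCC(Nc1ccc(CN(CCCc2c(N)nc(N)nc2O)c2cc(F)ccc2[N+](=O)[O-])cc1)C(=O)OC(C)(C)C` differs from compound 3 in more than a single place, so the difference between the two cores is not broken down here; in this assay compound 2 gives 8700 nM, the lowest of the three numbers, and its gap to compound 1 and to compound 3 lies beyond the scatter.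

Compound 4 `CC(C)(C)OC(=O)CCC(Nc1ccc(CN(CCCc2c(N)nc(N)nc2O)c2ccc([N+](=O)[O-])c(F)c2F)cc1)C(=O)OC(C)(C)C` has not yet been measured. It bears 2,3-difluoro-4-nitrophenyl in place of 5-fluoro-2-nitrophenyl on an amine nitrogen, the same change that turns compound 3 into compound 1, made on the same kind of amine nitrogen. Because that change gave only a 1.1-fold lower number from compound 3 to compound 1 (0.04 log units; within the scatter), the step from compound 2 to compound 4 is expected to be of similar small size, a 1.1-fold lower number from compound 2 to compound 4 (0.04 log units; within the scatter), with compound 2 remaining the point of reference. On that basis compound 4 is estimated at 8000 nM in this assay, most likely between 3500 nM and 20000 nM.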

Compound 4, half-maximal inhibitory concentration: 24000 nM
Compound 4: the middle estimate sits 3.0-fold (0.48 log units) below what was measured; the measured number lies above the stated range.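

In this assay, placing 2,3-difluoro-4-nitrophenyl in place of 5-fluoro-2-nitrophenyl on the amine nitrogen gives a 2.8-fold higher number from compound 2 to compound 4 (0.44 log units; beyond the scatter), so a change that made no readable difference on the core of compound 3 moves the number upward, towards a weaker inhibitor, on the core of compound 2. Within the data shown here, the same aryl swap therefore does not carry over from one core to the other at the same size, and the two steps differ by more than repeated measurement would explain: the same change on two cores in this assay, a 1.1-fold lower number (0.04 log units; within the scatter) from compound 3 to compound 1 and a 2.8-fold higher number (0.44 log units; beyond the scatter) from compound 2 to compound 4, 3.0-fold (0.48 log units) apart, beyond the scatter of two such steps What this does not show is which feature of the two cores lies behind the difference, and with only one pair on each core it gives no rule for how the swap would behave on any further core.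

The compounds shown leave open whether a free carboxylic acid in place of the tert-butyl esters would respond to the swap as the core of compound 2 does or as the core of compound 3 does. They also leave open whether a longer chain on the amine nitrogen, or a nitrile in place of the nitro group, would keep the two cores apart in the same way.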